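The source may hold more compounds than are shown below. What is called first, only, known or untested is meant among the compounds shown, and "the series" means these compounds.

Working notes on the series. Compound 1, `COc1ccc(-c2cc(-c3ccc(OC)c(OC)c3)cc(=O)[nH]2)c(OC)c1`, gives 1000 nM in a functional assay on MCF7 cells (Homo sapiens) for antiproliferative activity, read by MTT assay, with a stated time of 96 h (a higher number here means a weaker inhibitor, a lower number a stronger inhibitor), the lowest of the two numbers recorded. Among the measured compounds shown here, its nearest neighbour is compound 2, `COc1ccc(-c2cc(-c3ccc4c(c3)OCCO4)cc(=O)[nH]2)c(OC)c1`, for which this assay gives 2500 nM; that gap is beyond the usual scatter, so compound 1 stands as the stronger of the two measured entries, though with only two numbers no wider pattern can be drawn.

Compound 3, `COc1ccc(-c2cc(-c3ccc(OC)cc3OC)[nH]c(=O)c2)cc1`, has not yet been measured. Against compound 1 the change is hydrogen in place of methoxy on an aromatic carbon. For the measured compounds named here, no measured pair in the set shows this change, so its effect has to be guessed. The expectation is a small step in this assay, most likely toward a somewhat higher number, of a size that may not clear the scatter: the estimated step is a 1.5-fold higher number from compound 1 to compound 3 (0.18 log units; within the scatter). Compound 3 is therefore expected to give about 1500 nM, with a plausible range from 600 nM to 4000 nM.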

Compound 3, half-maximal inhibitory concentration: 500 nM
Estimate against measurement, compound 3: 3.0-fold (0.48 log units) above; measured number outside the range, below it.
By their numbers in this assay, from the lowest: compounds 3 and 1 (each within the scatter of the next); then compound 2.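

In this assay, among the compounds shown here, the first measured pair for hydrogen in place of methoxy on an aromatic carbon gives a 2.0-fold lower number from compound 1 to compound 3 (0.30 log units; within the scatter) and so does not separate the two compounds. The methoxy at this place, ortho to a methoxy group and meta to a large group, can therefore be removed without a step beyond the scatter, so this group is not required for the activity of compound 1 in this assay. No measurement on hand bears on the reason for this result.

As far as these compounds go, whether an amine, a fluorine atom or a longer chain such as ethoxy at this place would give a step beyond the scatter remains open. Also open, from the compounds shown here alone, is whether the remaining methoxy groups can be replaced by hydrogen in the same way.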